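The source may report more compounds than this note shows. Statements on the series, on what has been measured and on what is new or still open speak of the compounds shown alone.

Measured in a functional assay on HCT-116 cells (Homo sapiens) for inhibition, read by sulforhodamine B assay, with a stated time of 48 h; on this read-out higher numbers stand for weaker inhibition of growth and lower numbers for stronger inhibition of growth:
Compound 1 `CC(C)c1cc(C(=O)Nc2cccc(NC(=O)CCCCCCC(=O)NO)c2)c(O)cc1O`: 6230 nM
Compound 2 `CC(C)c1cc(C(=O)Nc2ccccc2NC(=O)CCCCCCC(=O)NO)c(O)cc1O`: 4920 nM

Going by the values given here, only these two compounds have numbers so far. Compound 1, at 6230 nM, and compound 2, at 4920 nM, lie within the usual scatter of each other, so the data do not separate them. Among the compounds with values here, compound 1 therefore stands level with the only other measured compound, and it serves here as the reference point.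

Compound 3 `CCN(C(=O)c1cc(C(C)C)c(O)cc1O)c1cccc(NC(=O)CCCCCCC(=O)NO)c1` has not yet been measured. It keeps the rest of compound 1 and differs in one place: ethyl in place of hydrogen on an amide-type nitrogen. In words, it carries ethyl in place of hydrogen on an amide-type nitrogen.

Within the data shown here, no measured pair shows what this change does in this assay, so any forecast is loose and its range has to be wide. A moderate move towards stronger inhibition of growth is expected, though a result within the scatter would not surprise. The expected step is a 2.2-fold lower number from compound 1 to compound 3 (0.35 log units; beyond the scatter). For compound 3 the estimated value is 2800 nM, with an expected range from 900 nM to 8000 nM.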

Compound 3, concentration for 50% growth inhibition: 1120 nM
Estimate against measurement, compound 3: 2.5-fold (0.40 log units) above, within the range that was stated.
By their numbers in this assay, from the lowest: compound 3; then compounds 2 and 1 (each within the scatter of the next).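

In this assay, going by these compounds alone, ethyl in place of hydrogen on the amide-type nitrogen, whose other neighbours are an aromatic carbon and a carbonyl carbon, gives a 5.6-fold lower number from compound 1 to compound 3 (0.75 log units; beyond the scatter), the first step that can be read. This shows that the amide hydrogen at this position is not required for inhibition of growth in these cells, and that a substituent here can move the number in the direction of stronger inhibition, a modest move but a real one against the scatter. Nothing available here accounts for the step, so the result describes what the change does and not how it does it.

The compounds shown place only ethyl and hydrogen on this nitrogen, so it remains open whether methyl, a longer chain such as propyl, or benzyl would give a smaller, similar or larger step. Going by these compounds, it also remains open whether ethyl on the corresponding amide-type nitrogen of compound 2 would give a step of similar size, or whether this step belongs to compound 1 alone.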